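From compound 1 to compound 4: one ring group exchanged

The source may hold more compounds than are shown below. What is called first, only, known or untested is meant among the compounds shown, and "the series" means these compounds.

Values in an ADME assay on MDBK cells (Bos taurus) for cytotoxicity, read by MTT assay (on this read-out higher numbers stand for lower toxicity in this test and lower numbers for higher toxicity in this test), as measured so far:
Compound 1 `CCCC1CCCCC1OCCCCCCN1C[C@H](O)[C@@H](O)[C@H](O)[C@H]1CO` gives 150000 nM
Compound 2 `OC[C@@H]1[C@@H](O)[C@H](O)[C@@H](O)CN1CCCCCCOC1CCCCC1C1CCCCC1` gives 200000 nM
Compound 3 `OC[C@@H]1[C@@H](O)[C@H](O)[C@@H](O)CN1CCC#CCCOc1cc(F)ccc1F` gives > 500000 nM as a limit of the assay

Compound 1 has one neighbour among these numbers, compound 2, and the two lie within the scatter of each other. The reading for compound 3 is a limit and not a number.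

Compound 4 `CC1CCCC(OCCCCCCN2C[C@H](O)[C@@H](O)[C@H](O)[C@H]2CO)C1C` has not yet been measured. The change that leads to it is a group of 8 heavy atoms (8 carbon; one six-membered non-aromatic ring of carbon only) in place of a group of 9 heavy atoms (9 carbon; one six-membered non-aromatic ring of carbon only), on an oxygen on a saturated carbon and the rest of compound 1 stays as it is. For the measured compounds named here, the one measured step that bears on this alters the same ring group: it gave a 1.3-fold higher number from compound 1 to compound 2 (0.12 log units; within the scatter) and so stayed small. No step beyond the scatter is therefore expected in this assay and no direction can be called. The expected step is a 1.1-fold higher number from compound 1 to compound 4 (0.03 log units; within the scatter) and it remains an estimate. For compound 4 the estimated value is 160000 nM with an expected range from 80000 nM to 320000 nM until the measurement is in.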

Compound 4, half-maximal cytotoxic concentration: > 500000 nM
Compound 4: no number, only a limit; the forecaster's own chance of this, stated with the estimate: 5%; at least 3.1-fold (0.49 log units) between middle value and limit.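

In this assay, for the compounds shown here, the ring group on this oxygen on a saturated carbon proves able to shift the read-out beyond the scatter, with a group of 8 carbon heavy atoms in place of one of 9 giving an at least 3.3-fold higher number from compound 1 to compound 4 (0.52 log units; beyond the scatter), whereas the only earlier exchange at this place, a 1.3-fold higher number from compound 1 to compound 2 (0.12 log units; within the scatter), did not show this. Compound 4 gives > 500000 nM, which is a limit of the assay and not a number. The step therefore has no upper end that can be read, and any further difference in this direction stays out of view: the limit of > 500000 nM in this assay, at which 2 of the 4 values shown sit.

The compounds shown leave open how a ring group bearing an amine or a carboxylic acid would read at this place. They also leave open whether a longer chain between this ring group and the shared core would change the result.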